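From dimethylamino to benzyloxy with only limits to go on

The source may hold more compounds than are shown below. What is called first, only, known or untested is meant among the compounds shown, and "the series" means these compounds.

In an ADME assay on Akata cells (Homo sapiens) for cytotoxicity, with a stated time of 7 days (on this read-out lower numbers stand for higher toxicity in this test and higher numbers for lower toxicity in this test), compound 3 (`CN(C)c1nc(N)nc2c1ncn2/C=C1/CC1(CO)CO`) gives > 24000 nM as a limit and not a number. Compound 1 (`Nc1nc(OCC(F)(F)F)c2ncn(/C=C3/CC3(CO)CO)c2n1`) gives > 20000 nM as a limit too. Compound 2 (`COCCOc1nc(N)nc2c1ncn2/C=C1/CC1(CO)CO`) likewise gives > 20000 nM as a limit. All three values are limits, so compound 3 has no readable rank among them.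

The move to compound 4 (`Nc1nc(OCc2ccccc2)c2ncn(/C=C3/CC3(CO)CO)c2n1`) places benzyloxy in place of dimethylamino on an aromatic carbon and brings in a six-membered aromatic ring of carbon only. Neither a step that the two limits leave unreadable from compound 1 to compound 3 nor a step that the two limits leave unreadable from compound 2 to compound 3 gives a size to carry over, although both change that same aromatic carbon. Compound 3 rests on the limit of > 24000 nM in this assay, at which 1 of the 3 values shown sits, so no step beyond the scatter is expected in this assay and no direction can be read. The estimated outcome is an at least 1.2-fold lower number from compound 3 to compound 4 (0.07 log units; that floor lies within the scatter) and remains only an expectation. Compound 4 is estimated at 20000 nM with an expected range from 7000 nM to 40000 nM in this read-out.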

Compound 4, half-maximal cytotoxic concentration: > 20000 nM
Compound 4: a limit, no number; the forecaster's own chance of this, stated with the estimate: 65%; the middle value lies on the limit itself.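

In this assay compound 4 gives > 20000 nM, a limit and not a number. For the compounds shown here, no step from compound 1, compound 2 or compound 3 to compound 4 can be read. The compounds shown leave open whether benzyloxy, dimethylamino, 2,2,2-trifluoroethoxy and 2-methoxyethoxy differ at all on that aromatic carbon.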